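Two limits and a blank before a chlorinated analogue

This account rests on a few compounds, and the source may have more. Where it says the series, first, only, none or still open, it means among the compounds named here.

Compound 1 `Cc1ccn2nc(C)c(C(=O)NCc3ccc(C(F)(F)F)cc3)c2c1` gives > 100000 nM in an ADME assay on Vero cells (Chlorocebus sabaeus) for cytotoxicity, read by CCK-8 assay, with a stated time of 72 h; on this read-out lower numbers stand for stronger inhibition and higher numbers for weaker inhibition; this is a limit of the assay, not a number.
Compound 2 `Cc1nn2cccc(C)c2c1C(=O)NCc1ccc(N2CCC(c3ccc(OC(F)(F)F)cc3)CC2)cc1` gives "not determined" (no result reported) in this assay, so no result was reported.
Compound 3 `Cc1nn2ccc(C(F)(F)F)cc2c1C(=O)NCc1ccc(N2CCC(c3ccc(OC(F)(F)F)cc3)CC2)cc1` gives > 100000 nM in this assay; this is again a limit and not a number.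

Where compound 2 stands is therefore open: of the three values shown, two sit at the limit and the third is missing, as summed up by the limit of > 100000 nM in this assay, at which 2 of the 3 values shown sit. Within the data shown here, no step between measured compounds that differ in one place is available, so the account can only describe what the two limits show, namely that compound 1 and compound 3 gave no measurable cytotoxicity within the range tested.

Compound 4 `CCc1nn2ccc(Cl)cc2c1C(=O)NCc1ccc(N2CCC(c3ccc(OC(F)(F)F)cc3)CC2)cc1` has not yet been measured. It differs from compound 2 by a group of 12 heavy atoms (9 carbon, 2 nitrogen, 1 chlorine; one five-membered aromatic ring with 2 hetero atoms, one six-membered aromatic ring with 1 hetero atom) in place of a group of 11 heavy atoms (9 carbon, 2 nitrogen; one five-membered aromatic ring with 2 hetero atoms, one six-membered aromatic ring with 1 hetero atom), on a carbonyl carbon. Since compound 2 has no number to start from, and the two neighbours that were measured both ended at the limit, the expectation for this step is that it changes nothing beyond the scatter and that compound 4 will likewise fail to show cytotoxicity within the range tested. Compound 4 is therefore expected to give about 100000 nM in this assay, within a range from 30000 nM to 300000 nM, most likely again reported only as a limit.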

Compound 4, half-maximal inhibitory concentration: > 100000 nM
Compound 4: no number, only a limit; the forecaster's own chance of this, stated with the estimate: 70%; the middle value sits exactly at the limit.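

In this assay compound 4 gives > 100000 nM, which is a limit and not a number. Among these compounds, compound 2 has no number either, so no step between compound 2 and compound 4 can be read. The compounds shown leave open at what concentration, if any, each would harm these cells, because the values stop at one limit: the limit of > 100000 nM in this assay, at which 3 of the 4 values shown sit.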